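A few compounds are considered here, and "the series" means these few. Any claim that something is new, unique, unknown or untested is made for them only; others in the source may bear on it.

Measured compounds:
compound 1 `CC1=C(C(=O)CC(C)C)C(c2ccoc2)NC(=O)N1` — 23%
compound 2 `CC1=C(c2ncc(C)o2)C(c2ccoc2)NC(=O)N1` — 21%

In an assay on membranes from CHO cells for displacement of a labelled ligand from adenosine receptor A1 (Homo sapiens), read by scintillation counting, with a stated time of 60 min, tested at 1 uM (on this read-out higher numbers stand for more inhibition at the one concentration tested (going by the name of the read-out) and lower numbers for less inhibition), compound 1 gives 23% and compound 2 gives 21%; the step of a number 2 percentage points lower from compound 1 to compound 2 (within the scatter) is within the scatter, so compound 1 stands with no separation from compound 2. Compound 3 `CCC(CC)OC(=O)C1=C(C)NC(=O)NC1c1ccoc1` differs from compound 1 by (pentan-3-yl)oxy in place of isobutyl on a carbonyl carbon. Among the measured compounds shown here, the only measured step touching this place, from the isobutylcarbonyl to the oxazolyl of compound 2, moved the number little, so no step beyond the scatter is expected here either. Compound 3 is therefore estimated at 22%, between 6% and 40%, a step of a number 1 percentage points lower from compound 1 to compound 3 (within the scatter).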

Compound 3, a percentage reported as inhibition, at one concentration (the size of the read-out at that concentration, not a potency): 17%
The estimate for compound 3 lay 5 percentage points above the measured number, within the range that was stated.
By their numbers in this assay, from the lowest: compounds 3, 2 and 1 (each within the scatter of the next).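

In this assay, (pentan-3-yl)oxy in place of isobutyl on a carbonyl carbon gives a number 6 percentage points lower from compound 1 to compound 3 (within the scatter), so the two numbers cannot be told apart, although the entering group has more heavy atoms and adds a hydrogen-bond acceptor. Three different groups at this place have now given numbers that lie within the scatter of one another. Nothing measured here bears on the reason for this result.

On these data alone, whether any group at this place can lift the number clear of the scatter remains open. An amine or a carboxylic acid on the carbonyl carbon, or a smaller methoxy group, could test this.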